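This account rests on a few compounds, and the source may have more. Where it says the series, first, only, none or still open, it means among the compounds named here.

Working notes on the sulfonate ester series.

Compound 1 `CCC(=O)Nc1ccc(S(=O)(=O)Oc2ccccc2C(C)C)cc1` gives 11000 nM in a functional assay on M21 cells (Homo sapiens) for antiproliferative activity, read by sulforhodamine B assay, with a stated time of 48 h; on this read-out higher numbers stand for weaker inhibition and lower numbers for stronger inhibition. Compound 2 `CCC(=O)Nc1ccc(S(=O)(=O)Oc2ccccc2I)cc1` gives 11000 nM in this assay; the step of no change at the digits printed from compound 1 to compound 2 (within the scatter) shows that exchanging iodo for isopropyl on the aromatic carbon leaves the read-out where it was. Compound 2 thus stands level with compound 1 at the digits shown, with no ordering between the two.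

The next compound is compound 3 `CC(C)(C)C(=O)Nc1ccc(S(=O)(=O)Oc2ccccc2I)cc1`. Its difference from compound 2 is tert-butyl in place of ethyl on a carbonyl carbon. Among the compounds with values here, the single measured step concerns the aromatic substituent, not the acyl group on the amide nitrogen, so no measured step bears directly on this change. What the series does show is a read-out that has not moved between the two measured compounds. With nothing to point in either direction, the expectation for this assay is a step of no change at the digits printed from compound 2 to compound 3 (within the scatter), that is, no change beyond the scatter. Compound 3 is therefore estimated at 11000 nM, within a range of 4000 nM to 30000 nM.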

Compound 3, half-maximal inhibitory concentration: 8300 nM
Estimate against measurement, compound 3: 1.3-fold (0.12 log units) above; the range from low to high includes it.
By their numbers in this assay, from the lowest: compounds 3, 1 and 2 (each within the scatter of the next).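

Within the data shown here, this is the first measured change at the carbonyl carbon whose other neighbour is the amide-type nitrogen, as the earlier step concerned only an aromatic carbon. In this assay tert-butyl, with 4 heavy atoms, in place of ethyl, with 2 heavy atoms, gives a 1.3-fold lower number from compound 2 to compound 3 (0.12 log units; within the scatter) and so leaves this place without a change that can be told apart from the scatter. Neither of the two single changes now on record moves the read-out beyond the scatter, and nothing at hand offers an explanation for this result.

One pair at this carbonyl carbon leaves open whether any other group placed there would move the read-out, for example a longer chain such as hexyl, a phenyl ring, or an aminomethyl group carrying a primary amine. Also open, on these data alone, is whether the exchange of iodo for isopropyl would read the same with tert-butyl on the carbonyl carbon, as that step stands only with ethyl there, and what a carboxylic acid on the aromatic carbon would do.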